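Chloro for fluoro on the 3,4-difluorophenyl amide

The compounds below may be only part of what the source reports. "The series", "measured", "known", "first", "only" and "open" are said of these compounds alone.

In a functional assay on A549 cells (Homo sapiens) for cytotoxicity, read by MTT assay, with a stated time of 72 h (on this read-out higher numbers stand for weaker inhibition and lower numbers for stronger inhibition), compound 2 `O=C(CN1CCN(c2nnc(Cc3ccccc3)c3ccccc23)CC1)Nc1ccc(F)c(F)c1` reads 10100 nM and holds the middle place, with compound 1 `COc1ccc(NC(=O)CN2CCN(c3nnc(Cc4ccncc4)c4ccccc34)CC2)cc1OC` higher at 26500 nM and compound 3 `O=C(CN1CCN(c2nnc(Cc3ccncc3)c3ccccc23)CC1)Nc1ccc(F)c(F)c1` lower at 3790 nM. Compound 4 `O=C(CN1CCN(c2nnc(Cc3ccccc3)c3ccccc23)CC1)Nc1ccc(F)c(Cl)c1` carries chloro in place of fluoro on an aromatic carbon, ortho to a fluoro group (chloro in place of fluoro on an aromatic carbon). The closest evidence is a modest change on the same aryl group (a 7.0-fold lower number from compound 1 to compound 3 (0.84 log units; beyond the scatter)), though that replaced both substituents. The other modest step (a 2.7-fold lower number from compound 2 to compound 3 (0.43 log units; beyond the scatter)) lies at the far end of the molecule. No swap of one halogen for another has been measured, so only a small change is expected, within the scatter (a 1.1-fold lower number from compound 2 to compound 4 (0.05 log units; within the scatter)). For compound 4 the estimated value is 9000 nM (expected range 4000 nM to 20000 nM).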

Compound 4, half-maximal inhibitory concentration: "not active" (no number reported)
For compound 4 the study gives words and no number; there is nothing to compare the estimate with.
By their numbers in this assay, from the lowest: compound 3; then compound 2; then compound 1.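

Going by these compounds alone, compound 4 is reported only in words, as not active, with no number, and no step from compound 2 can be read. From the compounds shown here alone, how chloro in place of fluoro shifts this read-out stays open, and no measured evidence bears on the result.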